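A thian-4-yl to 1-methylpyrrolidin-3-yl exchange

The source may report more compounds than this note shows. Statements on the series, on what has been measured and on what is new or still open speak of the compounds shown alone.

Going by the values given here, compound 2 `CC1(C)CCC(CN2CCN(c3ccc(C(=O)NS(=O)(=O)c4ccc(OCC5CCSCC5)c([N+](=O)[O-])c4)c(Oc4cnc5[nH]ccc5c4)c3)CC2)=C(c2ccc(C(F)(F)F)cc2)C1` holds the higher of the two numbers measured so far. In an assay on isolated protein for displacement of a labelled ligand from Apoptosis regulator Bcl-2 (Homo sapiens), with a stated time of 15 min (a higher number here means a weaker inhibitor, a lower number a stronger inhibitor), compound 2 gives 1.65 nM, whereas compound 1 `CCN(CC)CCCNc1ccc(S(=O)(=O)NC(=O)c2ccc(N3CCN(CC4=C(c5ccc(C(F)(F)F)cc5)CC(C)(C)CC4)CC3)cc2Oc2cnc3[nH]ccc3c2)cc1[N+](=O)[O-]` gives 0.3 nM. Among the compounds with values here, the single measured step, a 5.5-fold higher number from compound 1 to compound 2 (0.74 log units; beyond the scatter), replaced the whole side group on the aromatic carbon and is the only guide to how this region responds. Compound 3 `CN1CCC(COc2ccc(S(=O)(=O)NC(=O)c3ccc(N4CCN(CC5=C(c6ccc(C(F)(F)F)cc6)CC(C)(C)CC5)CC4)cc3Oc3cnc4[nH]ccc4c3)cc2[N+](=O)[O-])C1` differs from compound 2 by 1-methylpyrrolidin-3-yl in place of thian-4-yl on a saturated chain carbon bound to an oxygen on an aromatic ring. This change sits inside the same side group that was altered between compound 1 and compound 2, so a step of modest size, within or a little beyond the scatter, is expected, and its direction cannot be read from one step. Compound 3 is therefore expected to give about 1.2 nM in this assay, between 0.4 nM and 4 nM, a step of a 1.4-fold lower number from compound 2 to compound 3 (0.14 log units; within the scatter) that would leave compound 3 close to compound 2.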

Compound 3, half-maximal inhibitory concentration: 0.75 nM
The estimate for compound 3 lay 1.6-fold (0.20 log units) above the measured number, within the range that was stated.
By their numbers in this assay, from the lowest: compound 1; then compound 3; then compound 2.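

In this assay, the exchange of thian-4-yl for 1-methylpyrrolidin-3-yl on a saturated chain carbon bound to an oxygen on an aromatic ring gives a step beyond the scatter (a 2.2-fold lower number from compound 2 to compound 3 (0.34 log units; beyond the scatter)), so the ring here matters even with equal heavy-atom counts in the two groups. The (1-methylpyrrolidin-3-yl)methoxy group does not reach the number of the (3-(diethylamino)propyl)amino group on the aromatic carbon (a 2.5-fold higher number from compound 1 to compound 3 (0.40 log units; beyond the scatter)), and compound 1 stays lowest of the three. Nothing measured here accounts for either step.

Going by these compounds, this exchange alters ring size and hetero atom together, so the effect of each alone stays open; a 1-methylpiperidin-4-yl group would separate them. On these data alone, whether the oxygen or the nitrogen link on the aromatic carbon contributes to the remaining step also stays open, and a (1-methylpyrrolidin-3-yl)methylamino group would address that.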